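A few compounds are considered here, and "the series" means these few. Any claim that something is new, unique, unknown or untested is made for them only; others in the source may bear on it.

Measured compounds:
Compound 1 `COC(=O)CNc1nc(-c2ccccc2)nc2ccccc12` gives 36.3 ug/mL in a functional assay on A549 cells (Homo sapiens) for cytotoxicity, read by sulforhodamine B assay; on this read-out lower numbers stand for stronger inhibition and higher numbers for weaker inhibition.
Compound 2 `CC(C)Nc1nc(-c2ccccc2)nc2ccccc12` gives 7.53 ug/mL in this assay.

Compound 1 stands at the highest of the two numbers, its nearest neighbour being compound 2. Within the data shown here, the one step known, a 4.8-fold lower number from compound 1 to compound 2 (0.68 log units; beyond the scatter), came from putting isopropyl in place of (methoxycarbonyl)methyl on a nitrogen on an aromatic ring. Compound 3 `c1ccc(-c2nc(NC3CCCCC3)c3ccccc3n2)cc1` is not yet measured; it differs from compound 1 by cyclohexyl in place of (methoxycarbonyl)methyl on a nitrogen on an aromatic ring. Among the measured compounds shown here, this is a change of the same kind as the measured one, with a different saturated hydrocarbon replacing the same group at the same place, so the step from compound 1 to compound 2 is the only guide. A step of roughly that size and in the same direction is expected for compound 3, written as a 4.8-fold lower number from compound 1 to compound 3 (0.68 log units; beyond the scatter). Compound 3 is therefore estimated at 7.5 ug/mL in this assay, with a range from 3 ug/mL to 19 ug/mL.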

Compound 3, half-maximal inhibitory concentration: 7.23 ug/mL
For compound 3 the middle estimate is 1.0-fold (0.02 log units) above the measured one; low and high end bracket the measured number.
By their numbers in this assay, from the lowest: compounds 3 and 2 (each within the scatter of the next); then compound 1.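

In this assay, cyclohexyl in place of (methoxycarbonyl)methyl on the nitrogen gives a 5.0-fold lower number from compound 1 to compound 3 (0.70 log units; beyond the scatter), so a second saturated hydrocarbon group, this one with a six-membered non-aromatic ring of carbon only, moves the number the same way as isopropyl. With a 1.0-fold lower number from compound 2 to compound 3 (0.02 log units; within the scatter), isopropyl and cyclohexyl cannot be told apart at this place, so among these three compounds only the (methoxycarbonyl)methyl group stands apart. No evidence at hand bears on this result.

The compounds shown leave open whether the higher number of compound 1 goes with the methyl ester itself or with some other feature of that group. On these data alone, how a carboxylic acid, an amine-bearing chain or a longer chain such as n-butyl would read on this nitrogen also remains open.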